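Cyclopropylmethoxy added to the phenylpiperazine of compound 2

This account rests on a few compounds, and the source may have more. Where it says the series, first, only, none or still open, it means among the compounds named here.

Compound 2 `CN(C)C(=O)c1cccnc1NCCCN1CCN(c2ccccc2)CC1` stands highest of the two numbers measured in a functional assay for antagonist activity at Alpha-1A adrenergic receptor (Oryctolagus cuniculus) (on this read-out higher numbers stand for weaker binding and lower numbers for tighter binding), where compound 2 gives 6.31 nM; its nearest neighbour, compound 1 `COc1ccccc1N1CCN(CCCSc2ccccc2C(=O)N(C)C)CC1`, gives 2 nM in this assay, a gap beyond the scatter. Compound 3 `CN(C)C(=O)c1cccnc1NCCCN1CCN(c2ccccc2OCC2CC2)CC1` differs from compound 2 by cyclopropylmethoxy in place of hydrogen on an aromatic carbon. Among the measured compounds shown here, no measured step covers this change. Since compound 1, which also carries an alkoxy group, gives 2 nM, a modest tightening is expected from compound 2 to compound 3, a 2.1-fold lower number from compound 2 to compound 3 (0.32 log units; beyond the scatter), though it may stay within the scatter. Compound 3 is expected to give 3 nM, with a range of 1 nM to 10 nM.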

Compound 3, dissociation constant: 0.159 nM
Beside the measured number, compound 3's estimate is 19-fold (1.28 log units) above it, outside the stated range (below it).
By their numbers in this assay, from the lowest: compound 3; then compound 1; then compound 2.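

In this assay, cyclopropylmethoxy in place of hydrogen on an aromatic carbon, ortho to a large group, gives a 40-fold lower number from compound 2 to compound 3 (1.60 log units; beyond the scatter). Among the compounds shown here, this is the first measured change at this position, and it shows that this group there tightens binding strongly rather than merely being tolerated. Nothing shown accounts for the size of this step.

From the compounds shown here alone, whether the step depends on the oxygen or on the three-membered ring remains open. So does what a hydroxyl, an amine or a plain butyl chain would give at this position.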